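Hydrogen in place of fluoro on an aromatic carbon

The source may report more compounds than this note shows. Statements on the series, on what has been measured and on what is new or still open speak of the compounds shown alone.

In a toxicity assay on HUVEC cells (Homo sapiens) for inhibition, with a stated time of 72 h (a lower number here means a stronger inhibitor, a higher number a weaker inhibitor), compound 1 (`O=C(NO)c1ccc(CN(C2CC2)S(=O)(=O)c2cc(F)c(F)c(F)c2F)cc1`) gives 3900 nM and compound 2 (`CC(C)N(Cc1ccc(C(=O)NO)cc1)S(=O)(=O)c1c(F)c(F)c(F)c(F)c1F`) gives 3700 nM as the second reading of the series. These two values lie within the scatter of each other, so compound 2 stands level with compound 1 and no ranking can be drawn. Among the compounds with values here, no measured pair yet differs in one place only, so the series offers no direct step to read from.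

Compared with compound 2, compound 3 (`CC(C)N(Cc1ccc(C(=O)NO)cc1)S(=O)(=O)c1cc(F)c(F)c(F)c1F`) has hydrogen in place of fluoro on an aromatic carbon at a carbon ortho to a large group and para to a fluoro group. Compound 1 already carries hydrogen at that place and gives 3900 nM in this assay so no step beyond the scatter is expected, and no direction can be called. The estimated step of a 1.0-fold higher number from compound 2 to compound 3 (0.01 log units; within the scatter) is expected to stay within the scatter. Compound 3 is expected at 3800 nM with an estimated range from 1600 nM to 9000 nM for repeated measurements.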

Compound 3, half-maximal inhibitory concentration: 10100 nM
For compound 3 the middle estimate is 2.7-fold (0.42 log units) below the measured one; measured number outside the range, above it.
By their numbers in this assay, from the lowest: compounds 2 and 1 (each within the scatter of the next); then compound 3.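

In this assay, within the data shown here, the first single-place reading at this carbon, ortho to a large group and para to a fluoro group, is a 2.7-fold higher number from compound 2 to compound 3 (0.44 log units; beyond the scatter), so with isopropyl on the sulfonamide nitrogen, hydrogen in place of fluoro here moves the number upward beyond the scatter. With hydrogen held at this carbon, the sulfonamide nitrogen also shows a single-place effect: isopropyl in place of cyclopropyl gives a 2.6-fold higher number from compound 1 to compound 3 (0.41 log units; beyond the scatter), a modest step of similar size that places this substituent among the features that count in this assay. No accompanying measurement bears on the origin of either step.

On these data alone, the fluoro-to-hydrogen step is read only with isopropyl on the sulfonamide nitrogen, and the isopropyl-for-cyclopropyl step only with hydrogen at this carbon, so it remains open whether either step holds when the other place is changed. Also open, as far as these compounds go, is how a chloro group, a methoxy group or a nitrile at this carbon would read against fluoro and hydrogen.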